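The source may report more compounds than this note shows. Statements on the series, on what has been measured and on what is new or still open speak of the compounds shown alone.

Working notes on the series.

Compound 1 `COc1ccc(C2=NN(C3=NC(=O)/C(=C4\C(=O)Nc5ccc(Br)cc54)S3)C(c3ccc(OC)cc3)C2)cc1` gives 480 nM in a functional assay on cells (Cancer cell lines, Homo sapiens) for cytotoxicity, read by sulforhodamine B assay, with a stated time of 48 h; a lower number here means a stronger inhibitor of growth, a higher number a weaker inhibitor of growth. Compound 2 `COc1ccc(C2CC(c3ccc4ccccc4c3)=NN2C2=NC(=O)/C(=C3\C(=O)Nc4ccc(Br)cc43)S2)cc1` carries naphthalen-2-yl in place of 4-methoxyphenyl on a carbon with a double bond to nitrogen and in this assay compound 2 gives 990 nM; the step of a 2.1-fold higher number from compound 1 to compound 2 (0.31 log units; beyond the scatter) is modest but beyond the scatter. Compound 3 `COc1ccc(C2=NN(C3=NC(=O)/C(=C4\C(=O)Nc5ccccc54)S3)C(c3ccc(Cl)cc3)C2)cc1` sits on a different core; how the core of compound 3 differs from the core of compound 1 is not broken down here. In this assay compound 3 gives 100000 nM, the highest number of the three, far beyond the scatter from both compound 1 and compound 2.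

Compound 4 `O=C1N=C(N2N=C(c3ccc4ccccc4c3)CC2c2ccc(Cl)cc2)S/C1=C1/C(=O)Nc2ccccc21` is not yet measured. Among the measured compounds shown here, it carries naphthalen-2-yl in place of 4-methoxyphenyl on a carbon with a double bond to nitrogen, the same kind of change as the one from compound 1 to compound 2, though the surroundings differ: in compound 3 the ring atom two ring bonds away bears a 4-chlorophenyl group, where in compound 1 it bears a 4-methoxyphenyl group. For the measured compounds named here, the only precedent for this change is the step of a 2.1-fold higher number from compound 1 to compound 2 (0.31 log units; beyond the scatter), made on a core that is active; on the core of compound 3 the starting number is already the weakest seen, and whether the same direction carries over is open. The expectation for compound 4 in this assay is a step of about no change at the digits printed from compound 3 to compound 4 (within the scatter), resting on the direction of a 2.1-fold higher number from compound 1 to compound 2 (0.31 log units; beyond the scatter) and on the weak starting point of compound 3 at 100000 nM. Compound 4 is therefore estimated at 100000 nM, with a plausible range from 20000 nM to 250000 nM.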

Compound 4, concentration for total growth inhibition: 38300 nM
The estimate for compound 4 lay 2.6-fold (0.42 log units) above the measured number; low and high end bracket the measured number.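

In this assay the change to naphthalen-2-yl in place of 4-methoxyphenyl on a carbon with a double bond to nitrogen gives a 2.6-fold lower number from compound 3 to compound 4 (0.42 log units; beyond the scatter), and set beside the earlier step it does not carry over in direction: the same change on two cores in this assay, a 2.1-fold higher number (0.31 log units; beyond the scatter) from compound 1 to compound 2 and a 2.6-fold lower number (0.42 log units; beyond the scatter) from compound 3 to compound 4, 5.4-fold (0.73 log units) apart, beyond the scatter of two such steps. Across these two pairs, then, the change does not behave as a fixed increment that can be moved from one core to another, and the outcome on one core does not predict even the direction on the other. This does not show which difference between the cores matters: the two pairs differ both in the 4-chlorophenyl group against the 4-methoxyphenyl group and in the bromine on the core, and two pairs give no rule for any further core.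

The compounds shown leave open how the step behaves on a core with only one of these differences, either a bromine-bearing core with the 4-chlorophenyl group or a bromine-free core with the 4-methoxyphenyl group. They also leave open how other groups at this place compare with these two, such as an unsubstituted phenyl or a phenyl bearing an amine or a carboxylic acid.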